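A few compounds are considered here, and "the series" means these few. Any claim that something is new, unique, unknown or untested is made for them only; others in the source may bear on it.

Compound 1 `N#Cc1ccc(CN([C@H](CCC(F)(F)F)C(N)=O)S(=O)(=O)c2ccc(Cl)cc2)cc1`: 19.7 10^-6 cm/s
Compound 2 `N#C[C@H]1C[C@@H]1CN([C@H](CCC(F)(F)F)C(N)=O)S(=O)(=O)c1ccc(Cl)cc1`: 21.5 10^-6 cm/s
Compound 3 `N#C[C@@H]1C[C@H]1CN([C@H](CCC(F)(F)F)C(N)=O)S(=O)(=O)c1ccc(Cl)cc1`: 9.94 10^-6 cm/s

In an ADME assay on MDCKII-LE cells (Canis lupus familiaris) for permeability (on this read-out higher numbers stand for higher permeability and lower numbers for lower permeability), compound 3 gives 9.94 10^-6 cm/s. There is a 2.2-fold lower number from compound 2 to compound 3 (0.34 log units; beyond the scatter), a gap that stands on (the fact that compounds 2 and 3 differ only in the configuration as drawn). There is also a 2.0-fold lower number from compound 1 to compound 3 (0.30 log units; within the scatter).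

Compound 4 `C[C@]1(C#N)C[C@H](CN([C@H](CCC(F)(F)F)C(N)=O)S(=O)(=O)c2ccc(Cl)cc2)C1` carries 3-cyano-3-methylcyclobutyl in place of 2-cyanocyclopropyl on a saturated chain carbon bound to a sulfonamide nitrogen.

The nearest precedents are the earlier swaps of the group at this place, which gave a 1.1-fold higher number from compound 1 to compound 2 (0.04 log units; within the scatter) and a 2.0-fold lower number from compound 1 to compound 3 (0.30 log units; within the scatter). Both lie within the scatter, so no step beyond the scatter is expected in this assay. The expected change is a 1.4-fold higher number from compound 3 to compound 4 (0.15 log units; within the scatter). The estimate for compound 4 is 14 10^-6 cm/s, with an expected range of 7 10^-6 cm/s to 28 10^-6 cm/s.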

Compound 4, apparent permeability: 21.8 10^-6 cm/s
The estimate for compound 4 lay 1.6-fold (0.19 log units) below the measured number; the measured number falls inside the stated range.
By their numbers in this assay, from the lowest: compounds 3, 1, 2 and 4 (each within the scatter of the next, the first and the last beyond it).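

In this assay, a four-membered ring carrying a methyl group leaves the number where the 4-cyanophenyl and one cyclopropyl isomer put it, with a 1.1-fold higher number from compound 1 to compound 4 (0.04 log units; within the scatter) and a 1.0-fold higher number from compound 2 to compound 4 (0.01 log units; within the scatter). The same swap registers only when it starts from the other isomer, with a 2.2-fold higher number from compound 3 to compound 4 (0.34 log units; beyond the scatter). The size of this step therefore depends on the starting isomer, whose gap to its partner rests on one thing: the fact that compounds 2 and 3 differ only in the configuration as drawn

Still open, from the compounds shown here alone, is whether the ring or the methyl group matters here; a 3-cyanocyclobutyl group without the methyl would separate the two. Going by these compounds, the other configuration of compound 4 also remains open.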